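From a dihydroxypropyl amide to a methylpiperidine amide

This account rests on a few compounds, and the source may have more. Where it says the series, first, only, none or still open, it means among the compounds named here.

- compound 1 `Cc1c(C(=O)NCCCN(C)C)oc2ccc(N(Cc3ccc(Br)cc3)S(=O)(=O)c3ccc(Br)cc3)cc12`: 4310 nM
- compound 2 `Cc1c(C(=O)NCCS(C)(=O)=O)oc2ccc(N(Cc3ccc(Br)cc3)S(=O)(=O)c3ccc(Br)cc3)cc12`: > 40000 nM (a limit, not a number)
- compound 3 `Cc1c(C(=O)NCC(O)CO)oc2ccc(N(Cc3ccc(Br)cc3)S(=O)(=O)c3ccc(Br)cc3)cc12`: 30500 nM

In a functional assay on A549 cells (Homo sapiens) for antiproliferative activity, read by MTT assay, with a stated time of 48 h (a lower number here means a stronger inhibitor, a higher number a weaker inhibitor), compound 3 gives 30500 nM, the higher of the two true numbers. Compound 2 reports only a limit of the assay, > 40000 nM. Compound 4 `Cc1c(C(=O)N2CCCC(C)C2)oc2ccc(N(Cc3ccc(Br)cc3)S(=O)(=O)c3ccc(Br)cc3)cc12` carries 3-methylpiperidin-1-yl in place of (2,3-dihydroxypropyl)amino on a carbonyl carbon. Three measured steps change this same side chain, though none brings in a ring. The step of an at least 1.3-fold lower number from compound 2 to compound 3 (0.11 log units; that floor lies within the scatter) has a floor within the scatter, and an at least 9.2-fold higher number from compound 1 to compound 2 (0.96 log units; beyond the scatter) is at least modest. Compound 1 alone sits clearly lower, as a 7.1-fold higher number from compound 1 to compound 3 (0.85 log units; beyond the scatter) shows, so a smaller, modest move towards a lower number is expected in this assay. The expected change is a 2.2-fold lower number from compound 3 to compound 4 (0.34 log units; beyond the scatter). Compound 4 is estimated at 14000 nM, with a range from 4000 nM to 40000 nM.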

Compound 4, half-maximal inhibitory concentration: 33700 nM
The estimate for compound 4 lay 2.4-fold (0.38 log units) below the measured number; the range from low to high includes it.
By their numbers in this assay, from the lowest: compound 1; then compounds 3 and 4 (each within the scatter of the next). At a limit, above all of these: compound 2.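

In this assay, 3-methylpiperidin-1-yl in place of (2,3-dihydroxypropyl)amino on a carbonyl carbon, with 0 hydrogen-bond donors against 3, cannot be told apart from the open chain, the step being a 1.1-fold higher number from compound 3 to compound 4 (0.04 log units; within the scatter). The chain of compound 1, (3-(dimethylamino)propyl)amino, remains clearly apart from this ring, with a 7.8-fold higher number from compound 1 to compound 4 (0.89 log units; beyond the scatter). Compound 2 gives a limit, not a number: the limit of > 40000 nM in this assay, at which 1 of the 4 values shown sits. The step of an at least 1.1-fold lower number from compound 2 to compound 4 (0.07 log units; that floor lies within the scatter) has a floor within the scatter and cannot be read.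

Going by these compounds, whether a ring carrying a second nitrogen, such as 4-methylpiperazin-1-yl, would come closer to compound 1 stays open. So does what plain piperidin-1-yl, without the methyl, would give.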